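Swapping a Diol Side Chain for an Amine

The source may hold more compounds than are shown below. What is called first, only, known or untested is meant among the compounds shown, and "the series" means these compounds.

Compound 1, `CC1(C)CNC(=O)c2sc(Nc3ccc(I)cc3Cl)c(C(=O)NCC[C@@H](O)CO)c2C1`: 12100 nM
Compound 2, `CC1(C)CNC(=O)c2sc(Nc3ccc(I)cc3F)c(C(=O)NOCCO)c2C1`: 340 nM
Compound 3, `CC1(C)CNC(=O)c2sc(Nc3ccc(I)cc3F)c(C(=O)O)c2C1`: "not determined" (no result reported)

For the measured compounds named here, in a functional assay on HT-29 cells (Homo sapiens) for antiproliferative activity (on this read-out higher numbers stand for weaker inhibition and lower numbers for stronger inhibition), compound 1 gives 12100 nM, the highest of the two numbers known. Compound 2 gives 340 nM, a far lower number, a gap well beyond the usual scatter. Going by the values given here, compound 3 has no result in this assay, and no pair of measured compounds differs in only one place.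

Compound 4, `CC(C)(N)CNC(=O)c1c(Nc2ccc(I)cc2Cl)sc2c1CC(C)(C)CNC2=O`, differs from compound 1 in one place: 1-amino-1-methylethyl in place of 2,3-dihydroxypropyl on a saturated chain carbon bound to an amide-type nitrogen. Nothing measured isolates this change, so the expectation rests on compound 1 alone. Compound 4 is expected to show a modest gain, a step of a 4.0-fold lower number from compound 1 to compound 4 (0.61 log units; beyond the scatter) in this assay, somewhat beyond the scatter. The value of compound 4 is estimated at 3000 nM, within a range from 400 nM to 20000 nM.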

Compound 4, half-maximal inhibitory concentration: 113 nM
Compound 4: the middle estimate sits 27-fold (1.42 log units) above what was measured; the whole stated range lies above it.
By their numbers in this assay, from the lowest: compound 4; then compound 2; then compound 1.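

In this assay, this place on the side chain proves highly sensitive: 1-amino-1-methylethyl in place of 2,3-dihydroxypropyl gives a 110-fold lower number from compound 1 to compound 4 (2.03 log units; beyond the scatter) in a large step beyond the scatter. The change touches only this chain, so the chain alone can shift the read-out strongly while the shared core stays the same. Nothing available explains this gain. From the compounds shown here alone, it remains open whether the amine or the two methyl groups matter more. An unbranched 2-aminoethyl chain or a dimethylamino group at this place would help separate them.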